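A few compounds are considered here, and "the series" means these few. Any claim that something is new, unique, unknown or untested is made for them only; others in the source may bear on it.

Measured compounds:
compound 1, `COc1cc(O)c(C(=O)c2cccc(F)c2)c(OC)c1`: in a functional assay on THP-1 cells (Homo sapiens) for inhibition, read by ELISA, with stated times of 30 min and 24 h, tested at 10 uM (a higher number here means a stronger effect of the compound at the concentration tested, a lower number a weaker effect), compound 1 gives 81%
compound 2, `COc1cc(OC)c(C(=O)c2cccc(Cl)c2)c(O)c1CN1CCCC1`: in this assay compound 2 gives 81%

Compound 2 stands level with compound 1 at the digits printed. Its nearest neighbour among the measured compounds is compound 1, and the two readings show no change beyond the scatter. For the measured compounds named here, no pair of measured compounds that differ in one place has been compared, so no step size can be taken from the measurements themselves.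

Compound 3, `COc1cc(OC)c(C(=O)c2cccc(F)c2)c(O)c1CN1CCCC1`, has not yet been measured. It differs from compound 2 by fluoro in place of chloro on an aromatic carbon. Compound 1, which also carries fluoro on its ring, gives 81%, a reading that sits with that of compound 2. On this basis the step in this assay is expected to be small, with no change beyond the scatter and no particular direction.

Compound 3 is therefore estimated at 80% in this assay, with a range from 66% to 92%. The step this estimate means, a number 1 percentage points lower from compound 2 to compound 3 (within the scatter), is expected to stay within the scatter.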

Compound 3, a percentage reported as activity, at one concentration (the size of the read-out at that concentration, not a potency): 93%
Compound 3: the middle estimate sits 13 percentage points below what was measured, outside the stated range (above it).
By their numbers in this assay, from the lowest: compounds 1 and 2 (each within the scatter of the next); then compound 3.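

In this assay, for the compounds shown here, the halogen on this ring is not a neutral choice: fluoro in place of chloro on an aromatic carbon, meta to a large group, gives a number 12 percentage points higher from compound 2 to compound 3 (beyond the scatter) in a modest step beyond the scatter, which the earlier compounds could not show because no pair among them differed in one place. With fluoro held constant, (pyrrolidin-1-yl)methyl in place of hydrogen on an aromatic carbon gives a number 12 percentage points higher from compound 1 to compound 3 (beyond the scatter) as a second modest step beyond the scatter, so this side chain and the 3-chlorophenyl to 3-fluorophenyl change can each be read against a single structural difference, and compound 3 stands above both other compounds in this assay. The compounds shown offer no evidence that would explain either step.

Going by these compounds, whether the step for (pyrrolidin-1-yl)methyl would be of similar size with chloro on the ring remains open, as does whether a reading taken at one concentration would carry over to potency. On these data alone, it is also open how hydrogen, methoxy or trifluoromethyl would read in place of the halogen, and how morpholine or dimethylamine would read in place of the pyrrolidine.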